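Swapping Methoxy for Tert-Butyl in a Growth Inhibitor

A few compounds are considered here, and "the series" means these few. Any claim that something is new, unique, unknown or untested is made for them only; others in the source may bear on it.

Of the compounds shown here, two have been tested so far in a functional assay on SMMC-7721 cells (Homo sapiens) for inhibition, read by CCK-8 assay, with a stated time of 72 h, tested at 8 uM; on this read-out higher numbers stand for more inhibition of growth at the one concentration tested and lower numbers for less inhibition of growth. Compound 1 (`CCc1ccc(SCc2ccc(/C=C/C(=O)Nc3ccccc3N)cc2)cc1`) gives 19.5%, while compound 2 (`COc1ccc(SCc2ccc(C(=O)Nc3ccccc3N)cc2)cc1`) gives 80.1%, the higher of the two numbers and well beyond the usual scatter. These two compounds differ in more than one place, so their gap cannot be pinned on any single feature. Compound 3 (`CC(C)(C)c1ccc(SCc2ccc(C(=O)Nc3ccccc3N)cc2)cc1`) matches compound 2 except for one swap: tert-butyl in place of methoxy on an aromatic carbon. In words, tert-butyl sits in place of methoxy on an aromatic carbon, para to a large group. For the measured compounds named here, no measured pair shows this swap alone, so any expectation remains loose. With compound 2 at 80.1%, there is more room to fall than to rise. The estimated step is a number 14.1 percentage points lower from compound 2 to compound 3 (beyond the scatter), a moderate loss of inhibition slightly beyond the scatter. Compound 3 is expected to give 66%, with an estimated range of 40% to 88%.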

Compound 3, percent growth inhibition at one concentration: 46.1%
Beside the measured number, compound 3's estimate is 19.9 percentage points above it, within the range that was stated.
By their numbers in this assay, from the lowest: compound 1; then compound 3; then compound 2.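

Replacing methoxy with tert-butyl on an aromatic carbon, para to a large group, gives in this assay a number 34 percentage points lower from compound 2 to compound 3 (beyond the scatter) and so shows that growth inhibition at this position depends on which group is present. The swap changes two counted features at once: tert-butyl has more heavy atoms than methoxy, and it lacks the hydrogen-bond acceptor that methoxy carries. This single pair cannot separate those two differences, and no measurement at hand gives a reason for the loss.

As far as these compounds go, whether an amine or a hydroxyl group at this position would keep inhibition close to that of compound 2 remains open. Also open, from the compounds shown here alone, is whether a small group made only of carbon, such as methyl, would behave more like methoxy or more like tert-butyl.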